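The source may report more compounds than this note shows. Statements on the series, on what has been measured and on what is new or still open speak of the compounds shown alone.

Measured so far in a functional assay on MCF7 cells (Homo sapiens) for inhibition; a lower number here means a stronger inhibitor, a higher number a weaker inhibitor:
- compound 1 `CC/C(=C(/c1ccc(/C=C/C(=O)O)cc1)c1cc2ccccc2[nH]1)c1cccc(C(F)(F)F)c1`: 325 nM
- compound 2 `CC/C(=C(/c1ccc(/C=C/C(=O)O)cc1)c1cc2ccccc2[nH]1)c1ccc(C(F)(F)F)cc1`: 139 nM
- compound 3 `CC/C(=C(/c1ccc(/C=C/C(=O)O)cc1)c1cc2ccccc2[nH]1)c1cc(Cl)ccc1Cl`: 71 nM

Compound 1 gives the highest of the three numbers in this assay. The steps away from it are a 2.3-fold lower number from compound 1 to compound 2 (0.37 log units; beyond the scatter) and a 4.6-fold lower number from compound 1 to compound 3 (0.66 log units; beyond the scatter); between the other two, a 2.0-fold lower number from compound 2 to compound 3 (0.29 log units; within the scatter).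

Compound 4 `CC/C(=C(/c1ccc(/C=C/C(=O)O)cc1)c1cc2ccccc2[nH]1)c1ccc(Cl)c(C(F)(F)F)c1` differs from compound 1 by chloro in place of hydrogen on an aromatic carbon; cut one bond further out, the change reads 3-(trifluoromethyl)phenyl to 4-chloro-3-(trifluoromethyl)phenyl. Among the compounds with values here, no measured step adds a chloro to this ring while keeping the trifluoromethyl in place. Both measured steps from compound 1 alter this same aryl ring and both lowered the number modestly, so a modest lowering is expected here too, a 2.0-fold lower number from compound 1 to compound 4 (0.31 log units; beyond the scatter). Compound 4 is estimated at 160 nM, with a range of 60 nM to 420 nM.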

Compound 4, half-maximal inhibitory concentration: 2200 nM
For compound 4 the middle estimate is 14-fold (1.14 log units) below the measured one, outside the stated range (above it).
By their numbers in this assay, from the lowest: compounds 3 and 2 (each within the scatter of the next); then compound 1; then compound 4.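

In this assay, within the data shown here, chloro ortho to a trifluoromethyl group gives the first upward step on this aryl ring (a 6.8-fold higher number from compound 1 to compound 4 (0.83 log units; beyond the scatter)). The 4-chloro-3-(trifluoromethyl)phenyl ring also lies far from both other rings (a 16-fold higher number from compound 2 to compound 4 (1.20 log units; beyond the scatter); a 31-fold higher number from compound 3 to compound 4 (1.49 log units; beyond the scatter)), so chloro on the ring does not by itself go with a lower number, and compound 3 carries two chloro groups and goes against any such reading. Nothing at hand bears on the cause of this rise. Open, on these data alone, is whether a fluoro or a methyl at this position gives a similar rise. Also open, as far as these compounds go, is whether chloro here raises the number without the trifluoromethyl group.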